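The source may hold more compounds than are shown below. What is called first, only, known or untested is meant among the compounds shown, and "the series" means these compounds.

The measured compounds:
compound 1, `Cn1ccc2cc(-c3ccc4oc(NC5CCCCC5)nc4c3)ccc21`: 911 nM
compound 2, `CN(c1ccccc1)c1nc2cc(-c3ccc4c(ccn4C)c3)ccc2o1`: 68 nM
compound 3, `Cn1ccc2cc(-c3ccc4oc(Nc5cccnc5)nc4c3)ccc21`: 226 nM

All three were tested in an assay on HEK293 cells for inhibition of Fatty-acid amide hydrolase 1 (Homo sapiens), read by fluorescence; on this read-out lower numbers stand for stronger inhibition and higher numbers for weaker inhibition. Compound 3 stands second highest of the three numbers: its nearest neighbour is compound 2, with a 3.3-fold higher number from compound 2 to compound 3 (0.52 log units; beyond the scatter), and its furthest is compound 1, with a 4.0-fold lower number from compound 1 to compound 3 (0.61 log units; beyond the scatter). Compound 4, `C[C@@H]1CN(c2nc3cc(-c4ccc5c(ccn5C)c4)ccc3o2)C[C@H](C)O1`, has not yet been measured. It differs from compound 3 in one place: 2,6-dimethylmorpholin-4-yl in place of (pyridin-3-yl)amino on an aromatic carbon. For the measured compounds named here, two measured steps bear on this change. One gave a 13-fold lower number from compound 1 to compound 2 (1.13 log units; beyond the scatter), where a hydrogen-bond donor was lost from the amino group; another gave a 4.0-fold lower number from compound 1 to compound 3 (0.61 log units; beyond the scatter), where an aromatic ring took the place of a non-aromatic one. Compound 4 loses the hydrogen-bond donor, as compound 2 did, but returns to a non-aromatic ring, as in compound 1, so the two observations pull in opposite directions. For compound 4 a modest step is therefore expected, a 1.5-fold lower number from compound 3 to compound 4 (0.18 log units; within the scatter), most likely toward a somewhat lower number but possibly within the scatter. Compound 4 is estimated at 150 nM, with a range from 40 nM to 600 nM.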

Compound 4, half-maximal inhibitory concentration: 168 nM
Beside the measured number, compound 4's estimate is 1.1-fold (0.05 log units) below it; the measured number falls inside the stated range.
By their numbers in this assay, from the lowest: compound 2; then compounds 4 and 3 (each within the scatter of the next); then compound 1.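

In this assay, replacing (pyridin-3-yl)amino with 2,6-dimethylmorpholin-4-yl gives a 1.3-fold lower number from compound 3 to compound 4 (0.13 log units; within the scatter), so the two groups cannot be told apart here, even though only the group that leaves has an aromatic ring and a hydrogen-bond donor. A non-aromatic ring at this carbon is thus compatible with a number well under that of compound 1, as the change from cyclohexylamino shows with a 5.4-fold lower number from compound 1 to compound 4 (0.73 log units; beyond the scatter), yet methyl(phenyl)amino keeps its lead, with a 2.5-fold higher number from compound 2 to compound 4 (0.39 log units; beyond the scatter). Nothing measured here gives a reason for these steps.

From the compounds shown here alone, it remains open what the methyl groups and the ring oxygen of the morpholine each contribute, which plain morpholin-4-yl and piperidin-1-yl would help to separate. Also open, going by these compounds, is how methyl(pyridin-3-yl)amino or a small open-chain group such as dimethylamino would compare at this place.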